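This account rests on a few compounds, and the source may have more. Where it says the series, first, only, none or still open, it means among the compounds named here.

Compound 1 `N#Cc1cccc(-n2cc(-c3ccc(/C=C4\C(=O)Nc5ccccc54)cc3)nn2)c1`: in a functional assay on MKN-45 cells (Homo sapiens) for inhibition, read by CCK-8 assay, with a stated time of 24 h (on this read-out lower numbers stand for stronger inhibition and higher numbers for weaker inhibition), compound 1 reaches only the limit of > 20000 nM.
Compound 2 `O=C1Nc2ccccc2/C1=C/c1ccc(-c2cn(-c3ccc(Cl)c(C(F)(F)F)c3)nn2)cc1`: in this assay compound 2 gives 8890 nM.
Compound 3 `N#Cc1cccc(-n2cc(-c3ccc(/C=C4\C(=O)Nc5ccc(F)cc54)cc3)nn2)c1`: in this assay compound 3 reaches only the limit of > 20000 nM.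

All three share a core, and the unmeasured compound 4 `O=C1Nc2ccc(F)cc2/C1=C/c1ccc(-c2cn(-c3ccc(Cl)c(C(F)(F)F)c3)nn2)cc1` belongs to the same family. One change has already been tried once among the measured compounds: 4-chloro-3-(trifluoromethyl)phenyl in place of 3-cyanophenyl on an aromatic nitrogen. That change produced an at least 2.2-fold lower number from compound 1 to compound 2 (0.35 log units; beyond the scatter). The cores of compound 1 and compound 3 differ in a single point, (fluoro in place of hydrogen on an aromatic carbon). The step that the two limits leave unreadable from compound 1 to compound 3 cannot be given a size, as it rests on (the limit of > 20000 nM in this assay, at which 2 of the 3 values shown sit).

The move to compound 4 repeats the same change: 4-chloro-3-(trifluoromethyl)phenyl in place of 3-cyanophenyl on an aromatic nitrogen. The place is described in the same words as before, so it is the same change on a core that carries the extra fluoro. Within the data shown here, the step is expected to be an at least 2.5-fold lower number from compound 3 to compound 4 (0.39 log units; beyond the scatter), set beside the earlier at least 2.2-fold lower number from compound 1 to compound 2 (0.35 log units; beyond the scatter) as the only guide. In this assay compound 4 is therefore estimated at 8000 nM, with a likely range from 2500 nM to 25000 nM.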

Compound 4, half-maximal inhibitory concentration: > 20000 nM
Compound 4 ended at the assay's limit; the forecaster's own chance of this, stated with the estimate: 25%; middle value at least 2.5-fold (0.39 log units) from the limit.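

In this assay compound 4 gives > 20000 nM, which is a limit of the assay and not a number. The swap of 3-cyanophenyl for 4-chloro-3-(trifluoromethyl)phenyl on the fluoro core cannot be given a size, and neither can any other step with a limit at both ends, because those compounds sit at the same limit: the limit of > 20000 nM in this assay, at which 3 of the 4 values shown sit. What can be read is the comparison with the fluoro as the only difference, an at least 2.2-fold higher number from compound 2 to compound 4 (0.35 log units; beyond the scatter), so the measurable value reached on the core of compound 1 did not carry over to the fluoro core, though this does not show that the swap has no effect there.

Going by these compounds, whether the swap changes anything on the fluoro core remains open, as both compounds on that core give only a limit. Also open, on these data alone, is how the series would respond to a morpholine or a carboxylic acid on the phenyl ring, or to chloro in place of the fluoro.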